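A ring swap at one position of compound 1

The source may hold more compounds than are shown below. What is called first, only, known or untested is meant among the compounds shown, and "the series" means these compounds.

Compound 1 `CC(C)c1noc(N2CCC(Oc3cc(N4CCc5cc(N6CCCNS6(=O)=O)ccc54)ncn3)CC2)n1` gives 3.2 in a physicochemical assay for lipophilicity, measured as octanol-water partition, at pH 7.4; a lower number here means a more polar compound, a higher number a more lipophilic compound. Compound 2 `CC(C)c1noc(N2CCC(Oc3cc(N4CCc5cc(N6CCCS6(=O)=O)ccc54)ncn3)CC2)n1` gives 3.2 in this assay, and compound 3 `CC(C)SC(=O)N1CCC(Oc2cc(N3CCc4ccccc43)ncn2)CC1` gives 5.3. Compound 1 stands level with compound 2, the pair forming the lowest of the three numbers, while compound 3 lies higher by a gap beyond the scatter. Compound 4 `CC(C)c1noc(N2CCC(Oc3cc(N4CCc5cc(N6CCC(O)CC6=O)ccc54)ncn3)CC2)n1` differs from compound 1 by a group of 8 heavy atoms (5 carbon, 1 nitrogen, 2 oxygen; one six-membered non-aromatic ring with 1 hetero atom) in place of a group of 8 heavy atoms (3 carbon, 2 nitrogen, 2 oxygen, 1 sulfur; one six-membered non-aromatic ring with 3 hetero atoms), on an aromatic carbon. For the measured compounds named here, only one measured step touches this same aromatic carbon: no change at the digits printed from compound 1 to compound 2 (within the scatter), where one ring replaced another and the number did not move. Given no change at the digits printed from compound 1 to compound 2 (within the scatter), compound 4 is expected to show no step beyond the scatter, no change at the digits printed from compound 1 to compound 4 (within the scatter). Compound 4 is therefore estimated at 3.2, between 2.7 and 3.7.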

Compound 4, distribution coefficient: 2.8
The estimate for compound 4 lay 0.40 log units above the measured number; measured number inside the range.
By their numbers in this assay, from the lowest: compound 4; then compounds 1 and 2 (each within the scatter of the next); then compound 3.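

This position is not indifferent to every ring swap in this assay: the 4-hydroxy-2-oxopiperidin-1-yl ring gives a real drop (a number 0.40 log units lower from compound 1 to compound 4 (beyond the scatter)), and the same holds against the five-membered ring (a number 0.40 log units lower from compound 2 to compound 4 (beyond the scatter)). The group entering compound 4 matches the group leaving compound 1 in hydrogen-bond donors and acceptors, so those counts alone do not separate the two. Nothing available accounts for the step. Open, as far as these compounds go, is whether the ring hydroxyl carries this step, and how an amine or a carboxylic acid on this aromatic carbon would read.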